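Swapping bromo for methoxy on the outer ring

A few compounds are considered here, and "the series" means these few. Any claim that something is new, unique, unknown or untested is made for them only; others in the source may bear on it.

Two compounds of one series share a core, as seen in compound 1 `Cc1cc(CCC(=O)O)ccc1-c1noc(-c2ccc(OC(C)C)c(F)c2)n1` and compound 2 `Cc1cc(CCC(=O)O)ccc1-c1noc(-c2ccc(OC(C)C)c(Br)c2)n1`. In a functional assay on CHO cells with sphingosine 1-phosphate receptor 2 (Homo sapiens) as the target, read by GTPgammaS binding (on this read-out higher numbers stand for an effect only at larger amounts of compound and lower numbers for an effect already at smaller amounts), compound 1 gives > 10000 nM, which is a limit of the assay rather than a number. In this assay compound 2 gives > 10000 nM, again a limit rather than a number. Between them lies the step that the two limits leave unreadable from compound 1 to compound 2, and because of the limit of > 10000 nM in this assay, at which 2 of the 2 values shown sit, its size cannot be read. Compound 2 therefore stands where its value is known only as a limit, with no measured number to place it against.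

Compound 3 `COc1cc(-c2nc(-c3ccc(CCC(=O)O)cc3C)no2)ccc1OC(C)C` differs from compound 2 by methoxy in place of bromo on an aromatic carbon. Going by the values given here, the only measured step, a step that the two limits leave unreadable from compound 1 to compound 2, is unreadable and so gives no direction for this change; the two limits simply show that neither compound 1 nor compound 2 reached a measurable number. Compound 3 is therefore expected to behave much like compound 2, with the estimated step that the limit leaves unreadable from compound 2 to compound 3 leaving it near the same region. The expectation for compound 3 is a value of 15000 nM, within a range from 3000 nM to 60000 nM, quite possibly again reported only as a limit.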

Compound 3, half-maximal effective concentration: > 10000 nM
Compound 3 was reported as a limit (the forecaster's own chance of this, stated with the estimate: 75%); the middle value does not contradict the limit.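

In this assay compound 3 gives > 10000 nM, again a limit of the assay rather than a number. No step among compound 1, compound 2 and compound 3 can be read, because all three sit at the same limit: the limit of > 10000 nM in this assay, at which 3 of the 3 values shown sit.

The compounds shown leave open whether fluoro, bromo and methoxy differ at all in this assay.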